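A few compounds are considered here, and "the series" means these few. Any claim that something is new, unique, unknown or untested is made for them only; others in the source may bear on it.

Compound 1 `CCc1ccccc1NS(=O)(=O)c1cccc(NC(=O)NCCCCl)c1` and compound 2 `CCCc1ccccc1NS(=O)(=O)c1cccc(NC(=O)NCCCCl)c1` share one core and differ by methyl in place of hydrogen on a saturated chain carbon, two bonds along the chain from an aromatic carbon. In a functional assay on M21 cells (Homo sapiens) for cytotoxicity, read by sulforhodamine B assay, with a stated time of 48 h (on this read-out higher numbers stand for weaker inhibition and lower numbers for stronger inhibition), compound 1 gives > 200000 nM, which is a limit of the assay rather than a number; this is the limit of > 200000 nM in this assay, at which 1 of the 3 values shown sits. Compound 2 gives 23000 nM in this assay, so the pair shows an at least 8.6-fold lower number from compound 1 to compound 2 (0.93 log units; beyond the scatter). Compound 3 `CCNC(=O)Nc1cccc(S(=O)(=O)Oc2ccccc2C)c1` is built on a different core, and how that core differs from the core of compound 1 is not broken down here. In this assay compound 3 gives 51000 nM. Compound 4 `CCNC(=O)Nc1cccc(S(=O)(=O)Oc2ccccc2CC)c1` has not yet been measured; it differs from compound 3 by methyl in place of hydrogen on a saturated chain carbon bound to an aromatic carbon. Among the measured compounds shown here, this is the same kind of change as the one from compound 1 to compound 2, not the same: there the methyl enters on a saturated chain carbon two bonds along the chain from an aromatic carbon, here on a saturated chain carbon bound to an aromatic carbon. Beside the earlier step, compound 4 is expected to show a 2.6-fold lower number from compound 3 to compound 4 (0.41 log units; beyond the scatter) in this assay, a more cautious step, since an at least 8.6-fold lower number from compound 1 to compound 2 (0.93 log units; beyond the scatter) was read against a limit and the core and the place both differ. Compound 4 is therefore estimated at 20000 nM, between 5000 nM and 80000 nM.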

Compound 4, half-maximal inhibitory concentration: 30000 nM
Compound 4: the middle estimate sits 1.5-fold (0.18 log units) below what was measured; measured number inside the range.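

In this assay, methyl in place of hydrogen on a saturated chain carbon bound to an aromatic carbon, which turns 2-methylphenyl into 2-ethylphenyl, gives a 1.7-fold lower number from compound 3 to compound 4 (0.23 log units; within the scatter), a step no larger than the differences seen between repeated measurements. The size of this kind of change therefore did not carry over from one core to the other, even though the change is of the same kind: the same change on two cores in this assay, an at least 8.6-fold lower number (0.93 log units; beyond the scatter) from compound 1 to compound 2 and a 1.7-fold lower number (0.23 log units; within the scatter) from compound 3 to compound 4, at least 5.1-fold (0.70 log units) apart, beyond the scatter of two such steps This does not show whether the core or the exact place of the methyl accounts for the gap, and compound 1 stands at a limit of the assay, so the earlier step has no exact size: the limit of > 200000 nM in this assay, at which 1 of the 4 values shown sits.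

On these data alone, it remains open whether a longer chain than the ethyl of compound 4, or an amine or a carboxylic acid in that place, would move the number on the core of compound 3. With only two pairs shown, how the same change would behave on a third core also stays open.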